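Swapping an Arylamino for Dipropylamino on a Fused Core

This account rests on a few compounds, and the source may have more. Where it says the series, first, only, none or still open, it means among the compounds named here.

Compound 1 `Cc1ccc(NC2=CC(=O)c3nc4n(c3C2=O)[C@H]2OC[C@@H](O)[C@H]2OC4)cc1` is tested in a functional assay on MGC-803 cells (Homo sapiens) for inhibition, read by sulforhodamine B assay (a lower number here means a stronger inhibitor, a higher number a weaker inhibitor), and gives 1420 nM, the lower of the two numbers in hand. Compound 2 `CCOc1ccccc1NC1=CC(=O)c2c(nc3n2[C@H]2OC[C@@H](O)[C@H]2OC3)C1=O` gives 2830 nM in this assay, a number that lies within the usual scatter of the value of compound 1, so the two cannot be ordered. Compound 3 `CCCN(CCC)C1=CC(=O)c2nc3n(c2C1=O)[C@H]1OC[C@@H](O)[C@H]1OC3` has not yet been measured; it differs from compound 1 by dipropylamino in place of (4-methylphenyl)amino on a double-bonded ring carbon. For the measured compounds named here, no measured pair shows a change of this kind, so the direction rests on expectation alone. Compound 3 is expected to give a somewhat higher number, a step of a 2.8-fold higher number from compound 1 to compound 3 (0.45 log units; beyond the scatter) in this assay that may still fall within the scatter. The estimate for compound 3 is 4000 nM, between 1200 nM and 15000 nM.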

Compound 3, half-maximal inhibitory concentration: > 16000 nM
Compound 3 gave a limit, no number (the forecaster's own chance of this, stated with the estimate: 10%); at least 4.0-fold (0.60 log units) between middle value and limit.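

Dipropylamino in place of (4-methylphenyl)amino on a double-bonded ring carbon brings an at least 11-fold higher number from compound 1 to compound 3 (1.05 log units; beyond the scatter) in this assay, the first step that can be read at this place. The result for compound 3 is a limit of the assay, not a number: the limit of > 16000 nM in this assay, at which 1 of the 3 values shown sits.

The change removes the aromatic ring and the hydrogen-bond donor together, and the compounds shown do not separate the two. A propylamino group would keep the amine hydrogen without the ring, and an N-methyl-(4-methylphenyl)amino group would keep the ring without that hydrogen; neither is among them.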